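The source may report more compounds than this note shows. Statements on the series, on what has been measured and on what is new or still open speak of the compounds shown alone.

Compound 1 `FC(F)(F)c1ccc(Nc2nc(N3CCN(C4CCC4)CC3)nc3c2CCN(c2ncccc2C(F)(F)F)CC3)cc1` reads > 237 ug/mL in a physicochemical assay for solubility, in phosphate buffer, measured as thermodynamic solubility, at pH 2 (a lower number here means a less soluble compound, a higher number a more soluble compound), which is a limit and not a number. Going by the values given here, compound 2 `CC(=O)NC1CCN(c2nc3c(c(Nc4ccc(C(F)(F)F)cc4)n2)CCN(c2ncccc2C(F)(F)F)CC3)C1` gives 202 ug/mL, the only actual number in this assay so far. Compound 3 `FC(F)(F)c1ccc(Nc2nc(NC3CCCNC3)nc3c2CCN(c2ncccc2C(F)(F)F)CC3)cc1` has (piperidin-3-yl)amino in place of 3-acetamidopyrrolidin-1-yl on an aromatic carbon. Among the compounds with values here, one measured step bears on this change, an at least 1.1-fold lower number from compound 1 to compound 2 (0.06 log units; that floor lies within the scatter), and its size is only a floor, set by the limit of > 237 ug/mL in this assay, at which 1 of the 2 values shown sits. No step beyond the scatter is therefore expected, and the expected step is a 1.1-fold higher number from compound 2 to compound 3 (0.04 log units; within the scatter). The estimate for compound 3 is 220 ug/mL, with an expected range of 110 ug/mL to 420 ug/mL.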

Compound 3, solubility: > 235 ug/mL
Compound 3 gave a limit, no number; the forecaster's own chance of this, stated with the estimate: 35%; middle value at least 1.0-fold (0.02 log units) away from the limit.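

In this assay compound 3 gives > 235 ug/mL, a limit and not a number. On this aromatic carbon between two ring nitrogen atoms, (piperidin-3-yl)amino in place of 3-acetamidopyrrolidin-1-yl gives an at least 1.1-fold higher number from compound 2 to compound 3 (0.06 log units; that floor lies within the scatter), so the size of this change is known only as a floor: the limit of > 235 ug/mL in this assay, at which 1 of the 3 values shown sits. The step between compound 1 and compound 3 cannot be read, since both values are limits.

Going by these compounds, whether a carboxylic acid or a longer alkyl chain on this carbon gives a readable number in this assay stays open. On these data alone, the actual values of compound 1 and compound 3 also stay open.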